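Oxabicyclic replacement on the urea of compound 3

A few compounds are considered here, and "the series" means these few. Any claim that something is new, unique, unknown or untested is made for them only; others in the source may bear on it.

Measured compounds:
- compound 1 `COc1ccc(Cl)cc1C(=O)NCCC1CCN(S(=O)(=O)NC(=O)NC[C@@H]2C[C@@H]3CC[C@@H]2O3)CC1`: 30%
- compound 2 `O=C(NC1CCCCC1)NS(=O)(=O)N1CCC(CCNC(=O)c2cccc3c2OCCO3)CC1`: 34%
- compound 3 `O=C(NC[C@@H]1C[C@@H]2C=C[C@@H]1C2)NS(=O)(=O)N1CCC(CCNC(=O)c2cccc3c2OCCO3)CC1`: 11%

In a functional assay on the whole organism (blood) with Rattus norvegicus as the target, with stated times of 24 h and 1 h, at a dose of 5 mg/kg by the intraperitoneal route (on this read-out lower numbers stand for a weaker effect and higher numbers for a stronger effect at the one dose given), compound 3 stands lowest of the three numbers; compound 1 lies above it by a margin beyond the scatter, and compound 2 lies furthest above it, also beyond the scatter.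

Compound 4 `O=C(NC[C@@H]1C[C@@H]2CC[C@@H]1O2)NS(=O)(=O)N1CCC(CCNC(=O)c2cccc3c2OCCO3)CC1` is not yet measured. Its change from compound 3 is a group of 7 heavy atoms (6 carbon, 1 oxygen; 2 five-membered non-aromatic rings with 1 hetero atom each) in place of a group of 7 heavy atoms (7 carbon; 2 five-membered non-aromatic rings of carbon only), on a saturated chain carbon bound to an amide-type nitrogen.

Among the measured compounds shown here, the only measured step touching this end of the molecule is a number 23 percentage points lower from compound 2 to compound 3 (beyond the scatter), where the all-carbon bicyclic group gave the low number. For the measured compounds named here, no step joins the all-carbon bicyclic group directly to the oxygen-bridged one. Compound 1 carries the same entering group as compound 4 on a different aryl amide. Compound 1 gives 30%, and compound 2 gives 34%; both sit well above compound 3. On this basis a rise of moderate size is expected in this assay, though the direct evidence is thin.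

Compound 4 is therefore estimated at 22% in this assay, with a range of 8% to 38%, corresponding to an expected step of a number 11 percentage points higher from compound 3 to compound 4 (beyond the scatter).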

Compound 4, a percentage reported as activity, at one dose (the size of the read-out at that dose, not a potency): 15%
For compound 4 the middle estimate is 7 percentage points above the measured one; the range from low to high includes it.
By their numbers in this assay, from the lowest: compounds 3 and 4 (each within the scatter of the next); then compounds 1 and 2 (each within the scatter of the next).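

Notes on the group on the amide-type nitrogen, read in this assay: exchanging the all-carbon bicyclic group for the oxygen-bridged one gives a number 4 percentage points higher from compound 3 to compound 4 (within the scatter), so on this read-out the two groups cannot be told apart, and the double bond and ring carbon that leave, replaced by the ring oxygen that enters, make no visible difference. Measured against the six-membered carbon ring group, the oxygen-bridged group gives a number 19 percentage points lower from compound 2 to compound 4 (beyond the scatter), which sits with the earlier a number 23 percentage points lower from compound 2 to compound 3 (beyond the scatter) and shows that, with this aryl amide, the low number is not confined to the all-carbon bicyclic group. With the oxygen-bridged group held fixed, 2,3-dihydro-1,4-benzodioxin-5-yl in place of 5-chloro-2-methoxyphenyl on a carbonyl carbon gives a number 15 percentage points lower from compound 1 to compound 4 (beyond the scatter), so the number at this end also depends on the aryl amide carried at the other end.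

Still open, on these data alone, is how an amine or a carboxylic acid on the oxygen-bridged group, or a longer chain on the amide-type nitrogen, would read here, and how the six-membered carbon ring group would read with 5-chloro-2-methoxyphenyl. Nothing at hand bears on what lies behind these numbers.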